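The source may hold more compounds than are shown below. What is called first, only, known or untested is meant among the compounds shown, and "the series" means these compounds.

Measured so far:
- compound 1 `Nc1ncnc2c1nc(-c1ccco1)n2CCCO`: 350 nM
- compound 2 `Cn1c(-c2ccco2)nc2c(NC(=O)Nc3ccccc3)ncnc21`: 6250 nM

Compound 1 stands lowest of the two numbers in a functional assay on CHO cells for antagonist activity at adenosine receptor A2b (Homo sapiens); on this read-out lower numbers stand for stronger inhibition and higher numbers for weaker inhibition; compound 2 lies at a markedly higher number, well beyond the scatter. Going by the values given here, no step between measured compounds is available for the present change.

Compound 3 `Cn1c(-c2ccco2)nc2c(N)ncnc21` differs from compound 1 by hydrogen in place of 2-hydroxyethyl on a saturated chain carbon bound to an aromatic nitrogen. Without a comparable precedent, the step from compound 1 to compound 3 in this assay is expected to be small, likely a modest weakening or none beyond the scatter.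

Compound 3 is estimated at 600 nM, within 150 nM to 2500 nM, the expected step being a 1.7-fold higher number from compound 1 to compound 3 (0.23 log units; within the scatter).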

Compound 3, inhibition constant: 786 nM
The estimate for compound 3 lay 1.3-fold (0.12 log units) below the measured number, and the stated range covers the measured number.
By their numbers in this assay, from the lowest: compound 1; then compound 3; then compound 2.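

In this assay, going by these compounds alone, hydrogen in place of 2-hydroxyethyl on a saturated chain carbon bound to an aromatic nitrogen gives a 2.2-fold higher number from compound 1 to compound 3 (0.35 log units; beyond the scatter) as the first single-place step. The step is modest but beyond the scatter, so 3-hydroxypropyl gives the lower number at this position, and methyl stays within a modest step of it. Nothing measured here accounts for this difference.

Going by these compounds, whether the terminal hydroxyl or the chain itself matters remains open. A plain propyl chain or a 3-aminopropyl chain at this position would separate the two.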